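From hydroxymethyl to aminomethyl on a shared core

A few compounds are considered here, and "the series" means these few. Any claim that something is new, unique, unknown or untested is made for them only; others in the source may bear on it.

In a functional assay on CCRF-CEM cells (Homo sapiens) for antiproliferative activity, with a stated time of 72 h (on this read-out lower numbers stand for an effect already at smaller amounts and higher numbers for an effect only at larger amounts of compound), compound 3 (`Cc1cn([C@@H]2O[C@H](CO)[C@@H](CO)[C@@H]2O)c(=O)[nH]c1=O`) gives > 100 uM as a limit and not a number. Compound 1 (`Cc1cn([C@@H]2O[C@H](CO)[C@@H](CN=[N+]=[N-])[C@@H]2O)c(=O)[nH]c1=O`) gives > 100 uM as a limit too. Compound 2 (`Cc1cn([C@@H]2O[C@H](CO)[C@@H](CN)[C@H]2O)c(=O)[nH]c1=O`) gives > 100 uM as a limit as well. Compound 4 (`Cc1cn([C@@H]2O[C@H](CO)[C@@H](CN)[C@@H]2O)c(=O)[nH]c1=O`) is still unmeasured and has amino in place of hydroxy on a saturated chain carbon bound to a saturated ring carbon. Among the measured compounds shown here, the one measured step bearing on it is a step that the two limits leave unreadable from compound 1 to compound 3 and has no readable size, so the evidence amounts to the limit of > 100 uM in this assay, at which 3 of the 3 values shown sit, alone. For the measured compounds named here, no step of readable size is therefore expected in this assay and no direction can be given. The expected step is a step that the limit leaves unreadable from compound 3 to compound 4 by estimate. Compound 4 is expected at about 150 uM with an estimated range from 60 uM to 300 uM overall.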

Compound 4, concentration for half-maximal effect: > 100 uM
Compound 4: only a limit was reported; the forecaster's own chance of this, stated with the estimate: 85%; the middle value lies beyond the limit too.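

Compound 4 also gives only a limit, so its steps from compound 1, compound 2 and compound 3 cannot be read: the limit of > 100 uM in this assay, at which 4 of the 4 values shown sit.

The compounds shown leave open whether the change from hydroxymethyl to aminomethyl, or the configuration separating compound 2 from compound 4, affects this assay at all.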